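Swapping the Aryl Group Again: Benzothiazole on the Core

The source may hold more compounds than are shown below. What is called first, only, known or untested is meant among the compounds shown, and "the series" means these compounds.

Among the compounds with values here, compound 2 `O=C(O)CNC(=O)c1c(O)c2c(n(Cc3ccc(C(F)(F)F)nc3)c1=O)CCOC2` gives 6.8 nM in an assay on Sf9 cells for inhibition of prolyl hydroxylase EGLN2 (Homo sapiens), read by TR-FRET, with stated times of 30 min and 2 h (a higher number here means a weaker inhibitor, a lower number a stronger inhibitor), the higher of the two numbers measured so far, with compound 1 `N#Cc1ccc(Cn2c3c(c(O)c(C(=O)NCC(=O)O)c2=O)COCC3)c(F)c1` giving 6.3 nM in this assay, a gap that stays within the scatter. Compound 3 `O=C(O)CNC(=O)c1c(O)c2c(n(Cc3nc4ccccc4s3)c1=O)CCOC2` differs from compound 2 in one place: 1,3-benzothiazol-2-yl in place of 6-(trifluoromethyl)pyridin-3-yl on a saturated chain carbon bound to an aromatic nitrogen. Within the data shown here, the only measured step that bears on this change is the one from compound 1 to compound 2, also a swap of the aryl group on a saturated chain carbon bound to an aromatic nitrogen, which gave a 1.1-fold higher number from compound 1 to compound 2 (0.03 log units; within the scatter). Since that earlier swap left the number essentially unchanged, a step of similar size, in either direction or none beyond the scatter, is expected from compound 2 to compound 3, namely a 1.2-fold higher number from compound 2 to compound 3 (0.07 log units; within the scatter). Compound 3 is therefore estimated to give 8 nM in this assay, with a range from 3 nM to 25 nM.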

Compound 3, half-maximal inhibitory concentration: 3.3 nM
The estimate for compound 3 lay 2.4-fold (0.38 log units) above the measured number, within the range that was stated.
By their numbers in this assay, from the lowest: compounds 3, 1 and 2 (each within the scatter of the next, the first and the last beyond it).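

Within the data shown here, at this position on the saturated chain carbon bound to an aromatic nitrogen, changing the aryl group now moves the number beyond the scatter for the first time: a 2.1-fold lower number from compound 2 to compound 3 (0.31 log units; beyond the scatter) in this assay is a modest step, and it shows that a fused pair of aromatic rings with a five-membered ring at the point of attachment is accepted here. The same group set against the 4-cyano-2-fluorophenyl of the other compound gives a 1.9-fold lower number from compound 1 to compound 3 (0.28 log units; within the scatter) and stays within the scatter, so the benzothiazole stands clearly apart only from the 6-(trifluoromethyl)pyridin-3-yl group. Nothing measured here offers a reason for either step.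

Still open, as far as these compounds go, is whether the ring sulfur or the fused carbon ring matters more, which a 1,3-benzoxazol-2-yl or a plain 1,3-thiazol-2-yl group could test. A longer chain carrying the 1,3-benzothiazol-2-yl group is also unexplored in these compounds.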